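Aryl swap on the ring nitrogen; cytotoxicity outlook

This account rests on a few compounds, and the source may have more. Where it says the series, first, only, none or still open, it means among the compounds named here.

Working notes on the series. Compound 1 `CN1CCN(CCCNCc2cn(-c3ccc([N+](=O)[O-])cc3)nc2-c2ccc(Cl)cc2)CC1` carries a 4-nitrophenyl group and a 4-chlorophenyl group on the shared core; in an ADME assay on Huh-7 cells (Homo sapiens) for cytotoxicity (a lower number here means that less compound is tolerated, a higher number that more compound is tolerated), compound 1 gives 3700 nM. Compound 2 `Cc1ccccc1-c1nn(-c2ccccc2Cl)cc1CNCCN1CCN(C)CC1` carries a 2-methylphenyl group and a 2-chlorophenyl group on a related core. In this assay compound 2 gives > 20000 nM, which is a limit of the assay and not a number. Of the two values shown, one sits at that limit (the limit of > 20000 nM in this assay, at which 1 of the 2 values shown sits), so compound 2 stands at the tolerated end of what has been measured.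

Compound 3 `Cc1ccccc1-c1nn(-c2ccc(C(F)(F)F)cc2)cc1CNCCN1CCN(C)CC1` differs from compound 2 in one place: 4-(trifluoromethyl)phenyl in place of 2-chlorophenyl on an aromatic nitrogen. Among the measured compounds shown here, no step between measured compounds covers this kind of change, so no size can be read off. For this assay the step from compound 2 to compound 3 is expected to be small, an at least 1.1-fold lower number from compound 2 to compound 3 (0.04 log units; that floor lies within the scatter), not clearly beyond the scatter. Compound 3 is estimated at 18000 nM, within 7000 nM to 45000 nM, with a fair chance that only a limit is reported.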

Compound 3, half-maximal cytotoxic concentration: 11000 nM
Estimate against measurement, compound 3: 1.6-fold (0.21 log units) above; low and high end bracket the measured number.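

In this assay, among the compounds shown here, 4-(trifluoromethyl)phenyl in place of 2-chlorophenyl on the aromatic nitrogen gives an at least 1.8-fold lower number from compound 2 to compound 3 (0.25 log units; that floor lies within the scatter) as the first step that can be read at this position. The value of compound 2 is a limit of the assay and not a number, so only a floor for the step can be read, not its full size: the limit of > 20000 nM in this assay, at which 1 of the 3 values shown sits. That floor lies within the scatter, and a real drop in the tolerated concentration with this change is not established.

The swap alters both the substituent and its place on the phenyl ring, and the compounds shown do not separate the two. Going by these compounds, whether an unsubstituted phenyl, a 4-methoxyphenyl or a 2-(trifluoromethyl)phenyl on this nitrogen would stay at the limit remains open.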